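The source may report more compounds than this note shows. Statements on the series, on what has been measured and on what is new or still open speak of the compounds shown alone.

Measured in a functional assay on MDA-MB-231 cells (Homo sapiens) for antiproliferative activity, read by MTT assay, with a stated time of 48 h; on this read-out lower numbers stand for stronger inhibition and higher numbers for weaker inhibition:
Compound 1 `COc1ccc(N(C)c2ccnc(Cl)n2)cc1F`: 1280 nM
Compound 2 `COc1ccc(N(C)c2ccnc(Cl)n2)cc1OCCCCCBr`: > 10000 nM (a limit)

In this assay compound 2 stands at > 10000 nM, which is a limit of the assay and not a number. Within the data shown here, the one measured step, with (5-bromopentyl)oxy in place of fluoro on an aromatic carbon, is an at least 7.8-fold higher number from compound 1 to compound 2 (0.89 log units; beyond the scatter), and it lies beyond the scatter.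

Compound 3 `COc1ccc(N(C)c2ccnc(Cl)n2)cc1OCC[Se]C#N` alters the end of that chain: a group of 3 heavy atoms (1 carbon, 1 nitrogen, 1 selenium; no ring) in place of a group of 4 heavy atoms (3 carbon, 1 bromine; no ring), on a saturated chain carbon, two bonds along the chain from an oxygen on an aromatic ring. A group holding selenium and a triple bond thus replaces 3-bromopropyl. Among the measured compounds shown here, no measured step covers this exchange, so the step from compound 1 is only a loose guide to size. Compound 1 at 1280 nM shows that the shared core can give a number in this assay, and on that basis a move toward lower numbers of similar size is expected. A second limit remains possible for compound 3.

The expected shift is an at least 5.0-fold lower number from compound 2 to compound 3 (0.69 log units; beyond the scatter). For compound 3 the estimated value is 2000 nM, with an expected range of 300 nM to 10000 nM.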

Compound 3, half-maximal inhibitory concentration: 2750 nM
The estimate for compound 3 lay 1.4-fold (0.14 log units) below the measured number, within the range that was stated.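

The value of compound 2 is a limit of the assay and not a number: the limit of > 10000 nM in this assay, at which 1 of the 3 values shown sits. In this assay, as far as these compounds go, exchanging 3-bromopropyl, on a saturated chain carbon, two bonds along the chain from an oxygen on an aromatic ring, for the group holding selenium and a triple bond gives a measured number again, with an at least 3.6-fold lower number from compound 2 to compound 3 (0.56 log units; beyond the scatter), so a chain on this aromatic carbon does not by itself bring the value to a limit, and the true size of this step stays unknown. The fluoro of compound 1 still keeps the lower number, with a 2.1-fold higher number from compound 1 to compound 3 (0.33 log units; beyond the scatter), so the selenium chain brings the value back close to that of compound 1 without passing it.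

The compounds shown do not separate the part played by the selenium from that of the nitrile, and it remains open what a thiocyanate or a plain nitrile at the same chain end would give. Also open, from the compounds shown here alone, is how a longer chain with the same selenium end, or an amine or a carboxylic acid at that end, would compare.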